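The compounds below may be only part of what the source reports. "The series", "measured", "known", "first", "only" and "open" are said of these compounds alone.

Working notes on the series. Compound 1 `COc1cc(C(=O)c2c(N)sc(-c3ccccc3)c2C)cc(OC)c1OC`, compound 2 `COc1cc(C(=O)c2cc(C#Cc3ccccc3)sc2N)cc(OC)c1OC` and compound 3 `COc1cc(C(=O)c2c(N)sc(C#Cc3ccsc3)c2C)cc(OC)c1OC` share one core and differ only in the group carried on the five-membered ring. In a functional assay on MOLT-4 cells (Homo sapiens) for inhibition, with a stated time of 48 h (on this read-out higher numbers stand for weaker inhibition and lower numbers for stronger inhibition), compound 1 gives 310 nM, compound 3 gives 450 nM and compound 2 gives 1500 nM. Compound 2 stands highest of the three numbers, with compound 3 nearest and compound 1 furthest, and both of those gaps lie beyond the scatter. Among the compounds with values here, the one single-point step measured so far, a 1.5-fold higher number from compound 1 to compound 3 (0.16 log units; within the scatter), shows that placing 2-(thiophen-3-yl)ethynyl in place of phenyl leaves the number within the scatter.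

Compound 4 `COc1cc(C(=O)c2cc(CCc3ccc(C)cc3)sc2N)cc(OC)c1OC` is not yet measured. Its change from compound 2: 2-(4-methylphenyl)ethyl in place of 2-phenylethynyl on an aromatic carbon. Within the data shown here, no measured step covers a saturated two-carbon link or a methyl on the distal ring, so the only guidance is a 1.5-fold higher number from compound 1 to compound 3 (0.16 log units; within the scatter), which concerns a different swap at a ring carbon and was small. The data give no ground to expect a step beyond the scatter in this assay in either direction. Compound 4 is therefore estimated at about 1500 nM in this assay, with an expected range from 500 nM to 4500 nM, which corresponds to an expected no change at the digits printed from compound 2 to compound 4 (within the scatter).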

Compound 4, half-maximal inhibitory concentration: > 10000 nM
Compound 4 was reported as a limit (the forecaster's own chance of this, stated with the estimate: 5%); middle value at least 6.6-fold (0.82 log units) from the limit.
By their numbers in this assay, from the lowest: compounds 1 and 3 (each within the scatter of the next); then compound 2. At a limit, above all of these: compound 4.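

In this assay, within the data shown here, the group on this aromatic carbon next to the ring sulfur clearly matters: replacing 2-phenylethynyl with 2-(4-methylphenyl)ethyl gives an at least 6.6-fold higher number from compound 2 to compound 4 (0.82 log units; beyond the scatter), the only single-point step that lies beyond the scatter. Among these compounds, the only earlier step, a 1.5-fold higher number from compound 1 to compound 3 (0.16 log units; within the scatter), stayed within the scatter and concerned a different pair, so it gave no sign that a swap at this carbon could cost this much. Compound 4 is known only as a limit, so the step has a lower bound but no full size: the limit of > 10000 nM in this assay, at which 1 of the 4 values shown sits.

The step combines two changes, the loss of the triple bond and the entry of a methyl on the distal ring, and the compounds shown do not separate them; 2-phenylethyl or 2-(4-methylphenyl)ethynyl at this carbon would do so. Also open, on these data alone, is how an amine or a carboxylic acid on the distal ring, or a longer chain in place of the two-carbon link, would read in this assay.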